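The source may report more compounds than this note shows. Statements on the series, on what has been measured and on what is new or still open speak of the compounds shown alone.

Compound 1 `CNS(=O)(=O)c1ccc(-c2cnc(N)c(-c3ccc(OC)nc3)c2)cc1` was read in a physicochemical assay for solubility, read by nephelometry, measured as kinetic solubility, at pH 2 (on this read-out higher numbers stand for higher solubility and lower numbers for lower solubility), where compound 1 gives > 100 ug/mL, a limit of the assay rather than a number. Compound 2 `COc1ccc(-c2cc(-c3ccc(S(C)(=O)=O)c(F)c3)cnc2N)cn1` gives > 100 ug/mL, also a limit. Compound 3 `COc1ccc(-c2cc(-c3ccc4cnn(C)c4c3)cnc2N)cn1` gives > 100 ug/mL, again a limit.

Compound 1 therefore stands at the limit of > 100 ug/mL in this assay, at which 3 of the 3 values shown sit; no number separates it from the other two, as all three sit at that same limit. Compound 4 `COc1ccc(-c2cc(-c3ccc(C(=O)O)cc3)cnc2N)cn1` differs from compound 1 by carboxy in place of methylsulfamoyl on an aromatic carbon. Going by the values given here, no step between measured compounds is available to size this change. In this assay the step from compound 1 to compound 4 is expected to be an at least 1.2-fold lower number from compound 1 to compound 4 (0.09 log units; that floor lies within the scatter), a modest fall at most. Compound 4 is estimated at 80 ug/mL, ranging from 25 ug/mL to 200 ug/mL.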

Compound 4, solubility: 12.5 ug/mL
Compound 4: middle estimate off by 6.4-fold (0.81 log units), on the high side; measured number outside the range, below it.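

In this assay this position proves sensitive to what it carries: carboxy in place of methylsulfamoyl gives an at least 8.0-fold lower number from compound 1 to compound 4 (0.90 log units; beyond the scatter). Compound 4 is the first compound shown to give a number rather than a limit. The step remains a floor and not a full size because compound 1 stands at a limit: the limit of > 100 ug/mL in this assay, at which 3 of the 4 values shown sit.

The compounds shown leave open whether an amide or a methyl ester on this aromatic carbon would stay at the limit or fall as compound 4 does. They also leave open whether a longer chain ending in carboxy would give a similar fall.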